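Swapping pyrrolidin-1-yl for benzylamino on a carbonyl carbon

This account rests on a few compounds, and the source may have more. Where it says the series, first, only, none or still open, it means among the compounds named here.

In a functional assay on MCF7 cells (Homo sapiens) for antiproliferative activity, read by MTT assay, with a stated time of 24 h (a lower number here means a stronger inhibitor, a higher number a weaker inhibitor), compound 1 `CCCCc1oc2ccccc2c1C(=O)c1ccc(OCC(=O)Nc2ccccc2)cc1` gives 33600 nM and compound 3 `CCCCc1oc2ccccc2c1C(=O)c1ccc(OCCCC(=O)N2CCCC2)cc1` gives 23500 nM as measured numbers. The two stand level, with a 1.4-fold lower number from compound 1 to compound 3 (0.16 log units; within the scatter) as the gap between them. Compound 2 `CCCCNC(=O)CCCOc1ccc(C(=O)c2c(CCCC)oc3ccccc23)cc1` gives > 50000 nM as a limit of the assay. Compound 4 `CCCCc1oc2ccccc2c1C(=O)c1ccc(OCCCC(=O)NCc2ccccc2)cc1` carries benzylamino in place of pyrrolidin-1-yl on a carbonyl carbon. For the measured compounds named here, two steps bear on this. Pyrrolidin-1-yl in place of butylamino gave an at least 2.1-fold lower number from compound 2 to compound 3 (0.32 log units; beyond the scatter) as a modest drop, so benzylamino might raise the number again. Yet compound 1 with phenylcarbamoyl keeps its 33600 nM within the scatter of compound 3. In this assay the expected step is therefore a 1.5-fold higher number from compound 3 to compound 4 (0.17 log units; within the scatter) toward a higher number. Compound 4 is estimated at 35000 nM with 17000 nM to 50000 nM as its expected range.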

Compound 4, half-maximal inhibitory concentration: 49700 nM
Estimate against measurement, compound 4: 1.4-fold (0.15 log units) below; low and high end bracket the measured number.
By their numbers in this assay, from the lowest: compounds 3, 1 and 4 (each within the scatter of the next, the first and the last beyond it). At a limit, above all of these: compound 2.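

In this assay, benzylamino in place of pyrrolidin-1-yl on a carbonyl carbon gives a 2.1-fold higher number from compound 3 to compound 4 (0.33 log units; beyond the scatter). For the compounds shown here, this is the first step at this place measured between two actual numbers, and it shows that the group here can move the reading beyond the scatter, though only modestly. Phenyl in place of propyl on a saturated chain carbon bound to an amide-type nitrogen gives a number no higher from compound 2 to compound 4 (the limit leaves the size open). That step cannot be read, because compound 2 gives only a limit: the limit of > 50000 nM in this assay, at which 1 of the 4 values shown sits.

Benzylamino brings both an aromatic ring and an amide hydrogen, and these compounds do not tell which of them goes with the step. N-methylbenzylamino, which keeps the ring without that hydrogen, would separate the two.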